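Swapping Chloro for Methoxy on the Aryl Ring

A few compounds are considered here, and "the series" means these few. Any claim that something is new, unique, unknown or untested is made for them only; others in the source may bear on it.

Compound 1 `O=C(NCc1cn(Cc2ccc(Cl)cc2)nn1)c1cn(-c2ccccc2)nc1-c1ccc(Cl)cc1` gives 410 nM in a functional assay on MIA PaCa-2 cells (Homo sapiens) for antiproliferative activity, read by sulforhodamine B assay, with a stated time of 48 h; a higher number here means a weaker inhibitor of growth, a lower number a stronger inhibitor of growth. Among the measured compounds shown here, compound 2 `COc1cc(Cn2cc(CNC(=O)c3cn(-c4ccccc4)nc3-c3ccc(Cl)cc3)nn2)cc(OC)c1OC` gives 3500 nM, the higher of the two numbers so far, and the single measured step, an 8.5-fold higher number from compound 1 to compound 2 (0.93 log units; beyond the scatter), concerns a different part of the molecule. Compound 3 `COc1ccc(-c2nn(-c3ccccc3)cc2C(=O)NCc2cn(Cc3cc(OC)c(OC)c(OC)c3)nn2)cc1` differs from compound 2 by methoxy in place of chloro on an aromatic carbon. For the measured compounds named here, no measured step touches this position, so the expectation rests only on the value of compound 2 and stays wide. Compound 3 is expected to give 4000 nM, between 1500 nM and 12000 nM, a step of a 1.1-fold higher number from compound 2 to compound 3 (0.06 log units; within the scatter) that is expected to remain within the usual scatter.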

Compound 3, concentration for 50% growth inhibition: 31600 nM
Compound 3: the middle estimate sits 7.9-fold (0.90 log units) below what was measured, outside the stated range (above it).
By their numbers in this assay, from the lowest: compound 1; then compound 2; then compound 3.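

In this assay, the change from 4-chlorophenyl to 4-methoxyphenyl gives a 9.0-fold higher number from compound 2 to compound 3 (0.96 log units; beyond the scatter), so the group on this aromatic carbon clearly affects the reading. The earlier step concerned a different part of the molecule, so two separate places are now seen to shift the number beyond the scatter. Nothing available explains why this exchange gives a weaker inhibitor of growth. The compounds shown leave open how a fluoro group or an amine on this carbon would read. They also leave open whether the same exchange would give a step of similar size with the 4-chlorophenyl group of compound 1 at the other end of the molecule.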